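The compounds below may be only part of what the source reports. "The series", "measured", "known", "first", "only" and "open" are said of these compounds alone.

Going by the values given here, compound 3 `COc1ncnc2c1c(-c1ccco1)cn2[C@@H]1O[C@H](CO)[C@@H](O)[C@H]1O` is the only member of this small set with a number in a functional assay on K562 cells (Homo sapiens), read by MTT assay, with a stated time of 72 h (a lower number here means a stronger inhibitor, a higher number a weaker inhibitor), where compound 3 gives 60 nM. Compound 1 `COc1ncnc2c1c(-c1ccccc1)cn2[C@@H]1O[C@H](CO)[C@@H](O)[C@H]1O` is reported in this assay as a limit, compound 1 giving > 20000 nM. Compound 2 `CN(C)c1ncnc2c1c(-c1cc3ccccc3o1)cn2[C@@H]1O[C@H](CO)[C@@H](O)[C@H]1O` likewise sits at a limit, compound 2 giving > 20000 nM. Among the compounds with values here, the one measured step runs an at least 330-fold lower number from compound 1 to compound 3 (2.52 log units; beyond the scatter), so the aryl group on the shared core decides much here, and the limit of > 20000 nM in this assay, at which 2 of the 3 values shown sit, marks how little room the set leaves.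

Compound 4 `COc1ncnc2c1c(-c1cc3ccccc3o1)cn2[C@@H]1O[C@H](CO)[C@@H](O)[C@H]1O` is not yet measured. It differs from compound 3 by 1-benzofuran-2-yl in place of furan-2-yl on an aromatic carbon. Within the data shown here, no measured step covers this change directly; compound 2, which also carries 1-benzofuran-2-yl, shows only a limit. Given that, compound 4 is expected to lose ground against compound 3, the expected step being a 50-fold higher number from compound 3 to compound 4 (1.70 log units; beyond the scatter). Compound 4 is therefore estimated at 3000 nM, within a range from 300 nM to 20000 nM.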

Compound 4, half-maximal inhibitory concentration: 20900 nM
Compound 4: the middle estimate sits 7.0-fold (0.84 log units) below what was measured; measured number outside the range, above it.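

In this assay, the fused six-membered aromatic ring of carbon only is not tolerated at this aromatic carbon of the shared core, with methoxy held constant: the change to 1-benzofuran-2-yl gives a 350-fold higher number from compound 3 to compound 4 (2.54 log units; beyond the scatter). The furan ring present in both compounds is therefore not enough on its own to give a low number, and among the methoxy compounds shown, only furan-2-yl does so. The steps to compound 4 from compound 1 and from compound 2 cannot be read, since their values are limits: the limit of > 20000 nM in this assay, at which 2 of the 4 values shown sit.

The compounds shown leave open whether thiophen-2-yl, or a furan-2-yl carrying a methyl group, would keep the low number of compound 3. They also leave open how an amine in place of methoxy would behave alongside furan-2-yl.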